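This account rests on a few compounds, and the source may have more. Where it says the series, first, only, none or still open, it means among the compounds named here.

Measured in a functional assay on NCI-H460 cells (Homo sapiens) for cytotoxicity, read by MTT assay, with a stated time of 72 h; a lower number here means a stronger inhibitor, a higher number a weaker inhibitor:
compound 1 `O=c1[nH]/c(=C\c2nc[nH]c2C2CC2)c(=O)[nH]/c1=C\c1cccc(Oc2ccc(F)cc2)c1`: 15.2 nM
compound 2 `O=C(c1ccc(F)cc1)c1cccc(/C=c2\[nH]c(=O)/c(=C/c3nc[nH]c3C3CC3)[nH]c2=O)c1`: 2.8 nM

For the measured compounds named here, of these two numbers, compound 1 holds the higher, and the one measured step is a 5.4-fold lower number from compound 1 to compound 2 (0.73 log units; beyond the scatter). Compound 3 `O=c1[nH]/c(=C\c2c[nH]cn2)c(=O)[nH]/c1=C\c1cccc(Oc2ccc(F)cc2)c1` keeps the 4-fluorophenoxy group of compound 1 but carries hydrogen in place of cyclopropyl on an aromatic carbon. That measured step swaps a different group, so no measurement speaks directly to this change. It shows only that one substitution in this series can move the number beyond the scatter. The direction is therefore a judgement: losing the whole cyclopropyl ring is expected to raise the number, by a step at least as large as the measured one. The expected change is a 7.9-fold higher number from compound 1 to compound 3 (0.90 log units; beyond the scatter). Compound 3 is estimated at 120 nM, with an expected range from 25 nM to 600 nM.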

Compound 3, half-maximal inhibitory concentration: 479 nM
Estimate against measurement, compound 3: 4.0-fold (0.60 log units) below; measured number inside the range.
By their numbers in this assay, from the lowest: compound 2; then compound 1; then compound 3.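

In this assay, for the compounds shown here, the 5-cyclopropyl-1H-imidazol-4-yl to 1H-imidazol-4-yl change gives a 32-fold higher number from compound 1 to compound 3 (1.50 log units; beyond the scatter) and is the first measured step at this position, since compound 1 and compound 2 share the cyclopropyl group and differ only on the other side of the core. The number therefore depends strongly on what this aromatic carbon carries, and this step is larger than the other measured change, a 5.4-fold lower number from compound 1 to compound 2 (0.73 log units; beyond the scatter). No measurement shown here accounts for the rise in the number.

Among the compounds shown, only cyclopropyl and hydrogen are compared at this carbon, so it stays open whether a methyl group, an isopropyl group or a cyclobutyl ring would keep the number near that of compound 1. From the compounds shown here alone, it also stays open whether compound 2, with its (4-fluorophenyl)carbonyl group, would respond in the same way to hydrogen in place of cyclopropyl.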